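The source may hold more compounds than are shown below. What is called first, only, known or untested is meant among the compounds shown, and "the series" means these compounds.

Of the compounds shown here, three built on one shared core have been measured in a functional assay on L1210 cells (Mus musculus) for antiproliferative activity; a lower number here means a less potent compound, a higher number a more potent compound, by a factor of ten per unit of this negative logarithm. Compound 1 `CN(C)/N=N/c1ccc([N+](=O)[O-])cc1C(N)=O` gives 3.26. Compound 2 `C=CCN(C)/N=N/c1ccccc1C(N)=O` gives 3.43. Compound 3 `CCCCN(C)/N=N/c1ccc([N+](=O)[O-])cc1C(N)=O` gives 3.08, the lowest of the three numbers, although its gap to compound 1 lies within the scatter and only its gap to compound 2 lies beyond it. Among the measured compounds shown here, the single step that changes one place at a time, a number 0.18 log units lower from compound 1 to compound 3 (within the scatter), hardly moved the number. Compound 4 `CCCCN(C)/N=N/c1ccccc1C(N)=O` is still unmeasured; it arises from compound 3 by hydrogen in place of nitro on an aromatic carbon. For the measured compounds named here, no measured step removes the nitro group by itself: compound 1 and compound 2 differ there but also on the chain bound to the amine nitrogen, and their two values stand within the scatter of each other. With nothing bearing directly on this change, the number is expected to move little, a number 0.22 log units higher from compound 3 to compound 4 (within the scatter). Compound 4 is therefore estimated at 3.3, with a range from 2.8 to 3.8.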

Compound 4, logarithm of the reciprocal of the active concentration, log(1/C): 3.1
Beside the measured number, compound 4's estimate is 0.20 log units above it; low and high end bracket the measured number.
By their numbers in this assay, from the lowest: compounds 3, 4, 1 and 2 (each within the scatter of the next, the first and the last beyond it).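

Swapping nitro for hydrogen on this aromatic carbon, meta to a carbamoyl group, now has a direct reading in this assay: a number 0.02 log units higher from compound 3 to compound 4 (within the scatter). With this chain on the amine nitrogen, the numbers with and without the nitro group cannot be told apart. The chain does register among the compounds without nitro, where propyl in place of vinyl gives a modest step, a number 0.33 log units lower from compound 2 to compound 4 (beyond the scatter), and no measurement here explains the size of either step.

The compounds shown compare only hydrogen and nitro at this position, so it stays open whether an amine, a methoxy group or a chlorine atom there would leave the number just as unmoved. From the compounds shown here alone, whether the same swap behaves alike with the shorter chain of compound 1 also stays open.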